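Aryl Swap on a Spirocyclic Glucagon Receptor Antagonist

A few compounds are considered here, and "the series" means these few. Any claim that something is new, unique, unknown or untested is made for them only; others in the source may bear on it.

Compound 1 `CC(C)(C)CC[C@H](c1ccc(C(=O)NCc2nn[nH]n2)cc1)N1C(=O)C(c2cncc(Cl)c2)=N[C@]12CC[C@@H](C(C)(C)C)CC2`: 38 nM
Compound 2 `CC1(CC[C@H](c2ccc(C(=O)NCc3nn[nH]n3)cc2)N2C(=O)C(c3cc(Cl)cc(Cl)c3)=N[C@]23CC[C@@H](C(C)(C)C)CC3)CC1`: 17 nM
Compound 3 `C[C@H](c1ccc(C(=O)NCCC(=O)O)cc1)N1C(=O)C(c2ccc(F)cc2)=N[C@]12CC[C@@H](C(C)(C)C)CC2`: 85 nM

In an assay on CHO cells for displacement of a labelled ligand from Glucagon receptor (Homo sapiens), read by scintillation counting, with a stated time of 60 min (on this read-out lower numbers stand for stronger inhibition and higher numbers for weaker inhibition), compound 1 gives 38 nM, the second highest of the three numbers. Compound 2 gives 17 nM, a lower number, and the gap to compound 1 is beyond the scatter. Compound 3 gives 85 nM, a higher number, and that gap to compound 1 is also beyond the scatter. Going by the values given here, no pair of measured compounds differs in only one place, so no single-point step is available as a guide.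

Compound 4 `CC(C)(C)CC[C@H](c1ccc(C(=O)NCc2nn[nH]n2)cc1)N1C(=O)C(c2ccc(C(F)(F)F)cc2)=N[C@]12CC[C@@H](C(C)(C)C)CC2` has not been measured. It differs from compound 1 in one place: 4-(trifluoromethyl)phenyl in place of 5-chloropyridin-3-yl on a carbon with a double bond to nitrogen. All three measured compounds carry an aromatic group at this position and fall within a narrow band, so the step of a 1.3-fold lower number from compound 1 to compound 4 (0.10 log units; within the scatter) is expected to stay within the scatter, with no clear direction. Compound 4 is therefore expected to give 30 nM, in the range 10 nM to 100 nM.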

Compound 4, half-maximal inhibitory concentration: 7 nM
Beside the measured number, compound 4's estimate is 4.3-fold (0.63 log units) above it; measured number outside the range, below it.
By their numbers in this assay, from the lowest: compound 4; then compound 2; then compound 1; then compound 3.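

In this assay the change from 5-chloropyridin-3-yl to 4-(trifluoromethyl)phenyl gives a clear gain (a 5.4-fold lower number from compound 1 to compound 4 (0.73 log units; beyond the scatter)). Going by these compounds alone, this is the first single-place step, and it shows that the aromatic group on this carbon with a double bond to nitrogen can shift the number beyond the scatter. Nothing available explains this step.

The ring and its substituents change together, so their shares of the step remain unseparated. On these data alone, it also remains open how a nitrile or an amine in place of trifluoromethyl would read out.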